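Methoxy to Trifluoromethyl: An Expected Antiproliferative Step

A few compounds are considered here, and "the series" means these few. Any claim that something is new, unique, unknown or untested is made for them only; others in the source may bear on it.

Three compounds have been measured in a functional assay on BJAB cells (Homo sapiens) for antiproliferative activity, with a stated time of 4 days; a higher number here means that more compound is needed for the effect, a lower number that less compound is needed:

Compound 1 `Cc1c(-c2cc(Cl)cc(Cl)c2)c(C(=O)O)nn1-c1nc(-c2cc(Cl)ccc2F)c(SC(C)C)s1`: 4800 nM
Compound 2 `Cc1c(-c2cc(Cl)cc(Cl)c2)c(C(=O)O)nn1-c1nc(-c2ccncc2)c(SC(C)C)s1`: "not active" (no number reported)
Compound 3 `COc1ccccc1-c1c(C)nn(-c2nc(-c3ccc(Cl)c(Cl)c3)c(SC(C)C)s2)c1C(=O)O`: 14700 nM

Compound 2 is reported only as not active, without a number. Of the two compounds with numbers, compound 3 stands at the highest value, and its nearest neighbour is compound 1, whose number lies below it by a gap beyond the scatter. The pair does not share a single point of difference, so nothing can be said of what any one change does.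

Compound 4 `Cc1nn(-c2nc(-c3ccc(Cl)c(Cl)c3)c(SC(C)C)s2)c(C(=O)O)c1-c1ccccc1C(F)(F)F` is the compound still to be tested. It differs from compound 3 by trifluoromethyl in place of methoxy on an aromatic carbon. Going by the values given here, none of the measured compounds shows this change, so the direction of its effect is not known from the data. Compound 4 is therefore expected to land close to compound 3, with the step of a 1.3-fold lower number from compound 3 to compound 4 (0.13 log units; within the scatter) small and likely within the scatter. The estimate for compound 4 in this assay is 11000 nM, with a range from 3000 nM to 40000 nM.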

Compound 4, half-maximal effective concentration: 5200 nM
For compound 4 the middle estimate is 2.1-fold (0.33 log units) above the measured one, and the stated range covers the measured number.
By their numbers in this assay, from the lowest: compounds 1 and 4 (each within the scatter of the next); then compound 3.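

In this assay, going by these compounds alone, the change from 2-methoxyphenyl to 2-(trifluoromethyl)phenyl provides the first step in this set that can be read at a single point of difference: a 2.8-fold lower number from compound 3 to compound 4 (0.45 log units; beyond the scatter), a modest shift that lies beyond the usual scatter. It shows that this place on the aromatic ring, ortho to a large group, is not indifferent to what it carries, and that, in this one pair, trifluoromethyl goes with less compound being needed than methoxy. Nothing shown here gives a measured reason for this step.

From the compounds shown here alone, what remains open is how other groups at this place would behave, such as a nitrile, an amine or a single fluorine. Going by these compounds, it is also open whether the same exchange would give a step of similar size on a compound with other changes elsewhere, such as compound 1.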